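Can Two More Methoxy Groups Revive an Inactive Compound?

This account rests on a few compounds, and the source may have more. Where it says the series, first, only, none or still open, it means among the compounds named here.

In a functional assay on PC-3 cells (Homo sapiens) for inhibition, read by sulforhodamine B assay, with a stated time of 48 h, tested at 50 uM (a higher number here means more inhibition of growth at the concentration tested, a lower number less inhibition of growth), compound 1 (`COc1ccc(/C=C/C(=O)/C=C/c2ccc(OCc3cn(CCCCCOc4cc(=O)oc5ccccc45)nn3)c(OC)c2)cc1OC`) is reported as "not active" (no number reported) and has no figure to work with. Compound 2 (`COc1ccc(/C=C/C(=O)/C=C/c2ccc(OCc3cn(CCCCCOc4cc(=O)oc5ccccc45)nn3)c(OC)c2)cc1`) is likewise reported as "not active" (no number reported) and so has no single number, a standing it shares with compound 1. Compound 3 (`COc1ccc(/C=C/C(=O)/C=C/c2ccc(OCc3cn(CCCOc4cc(=O)oc5ccccc45)nn3)c(OC)c2)cc1OC`) gives 9% and supplies the only figure so far.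

Compound 4 (`COc1cc(/C=C/C(=O)/C=C/c2cc(OC)c(OC)c(OC)c2)ccc1OCc1cn(CCCCCOc2cc(=O)oc3ccccc23)nn1`) has not yet been measured. It departs from compound 2 in one place, on a double-bonded chain carbon bound to a double-bonded chain carbon: 3,4,5-trimethoxyphenyl in place of 4-methoxyphenyl on a double-bonded chain carbon bound to a double-bonded chain carbon (3,4,5-trimethoxyphenyl in place of 4-methoxyphenyl).

Going by the values given here, no measured pair shows what this swap does, so any forecast is loose. The expectation in this assay is no step beyond the usual scatter, with no clear direction. Among the compounds with values here, it rests on compound 2 at "not active" (no number reported) and on compound 3 at 9% as the only reading available.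

Compound 4 is expected at 8% with an estimated range of 0% to 25% if a number is reported at all.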

Compound 4, percent growth inhibition at one concentration: "not active" (no number reported)
The entry for compound 4 holds no number, so the estimate cannot be set against anything.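

Going by these compounds alone, compound 2 and compound 4 are both reported without a number in this assay, so no step between them can be read. Nothing available explains this result. On these data alone, whether 3,4,5-trimethoxyphenyl in place of 4-methoxyphenyl changes growth inhibition at all remains open.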